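A few compounds are considered here, and "the series" means these few. Any claim that something is new, unique, unknown or untested is made for them only; others in the source may bear on it.

Of the compounds shown here, three built on the same core have been measured in an assay on LtK cells with ATP-sensitive inward rectifier potassium channel 11 (Homo sapiens) as the target; a lower number here means that less compound is needed, a higher number that more compound is needed for the effect. Compound 1 `O=C(Nc1ccc(Cl)cc1)Nc1c(C(O)(C(F)(F)F)C(F)(F)F)ccc2ccccc12` gives 276 nM, compound 2 `Cc1ccccc1C(=O)Nc1c(C(O)(C(F)(F)F)C(F)(F)F)ccc2ccccc12` gives 5550 nM, and compound 3 `O=C(Nc1c(C(O)(C(F)(F)F)C(F)(F)F)ccc2ccccc12)c1cccc(C(F)(F)F)c1` gives 84 nM. Compound 3 therefore stands lowest of the three: its nearest neighbour is compound 1, and the step of a 3.3-fold lower number from compound 1 to compound 3 (0.52 log units; beyond the scatter) is modest, while the step of a 66-fold lower number from compound 2 to compound 3 (1.82 log units; beyond the scatter) is large.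

Compound 4 `O=C(Nc1c(C(O)(C(F)(F)F)C(F)(F)F)ccc2ccccc12)c1cc(Cl)cc(Cl)c1` departs from compound 3 by one change: 3,5-dichlorophenyl in place of 3-(trifluoromethyl)phenyl on a carbonyl carbon.

Among the measured compounds shown here, the one measured step that bears directly on this kind of change is a 66-fold lower number from compound 2 to compound 3 (1.82 log units; beyond the scatter). For the measured compounds named here, both partners there carry an aryl group on the carbonyl carbon and only that aryl group differs. That step is large, so changes of the aryl group on the carbonyl carbon have already proven able to move this assay a long way. The step of a 20-fold higher number from compound 1 to compound 2 (1.30 log units; beyond the scatter) is also large but mixes an amino-bearing group with an aryl group, so it bears less directly. Going by the values given here, no measured pair shows what trading a single trifluoromethyl for two chlorines does, and the direction is open. Compound 4 is expected to stay in the neighbourhood of compound 3, with the step of a 1.8-fold higher number from compound 3 to compound 4 (0.25 log units; within the scatter) being the estimate. Compound 4 is thus estimated at 150 nM, in a range from 40 nM to 600 nM.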

Compound 4, half-maximal effective concentration: 306 nM
Compound 4: middle estimate off by 2.0-fold (0.31 log units), on the low side; measured number inside the range.
By their numbers in this assay, from the lowest: compound 3; then compounds 1 and 4 (each within the scatter of the next); then compound 2.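

In this assay, the swap at the carbonyl carbon shows that 3,5-dichlorophenyl cannot simply stand in for 3-(trifluoromethyl)phenyl, as the change gives a 3.6-fold higher number from compound 3 to compound 4 (0.56 log units; beyond the scatter) and so costs a modest but real part of what compound 3 reached. The 3,5-dichlorophenyl group still stays well clear of the 2-methylphenyl group, with an 18-fold lower number from compound 2 to compound 4 (1.26 log units; beyond the scatter), and it matches the (4-chlorophenyl)amino group of compound 1, with a 1.1-fold higher number from compound 1 to compound 4 (0.04 log units; within the scatter), so two quite different groups on the carbonyl carbon give numbers that cannot be told apart here. No evidence is available on what lies behind the step from compound 3 to compound 4.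

The compounds shown leave open whether a phenyl ring carrying one chlorine, two trifluoromethyl groups, a nitrile or a methoxy group would follow compound 3 or compound 4. They also leave open how far a pyridine ring, a saturated cyclohexyl ring, or a phenyl ring bearing an amine or a carboxylic acid would be tolerated on the same carbonyl carbon.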